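Swapping the Side Chain of Compound 3

This account rests on a few compounds, and the source may have more. Where it says the series, first, only, none or still open, it means among the compounds named here.

Within the data shown here, the three compounds measured so far are compound 1 `N=C(N)NCCC[C@H](NC(=O)CN(c1nc(Cl)nc2[nH]cnc12)C1CC1)C(=O)O`, compound 2 `N=C(N)NCCC[C@H](NC(=O)CN(c1nc(Cl)nc2[nH]cnc12)C1CC1)C(=O)OCc1ccccc1` and compound 3 `C[C@@H](O)[C@H](NC(=O)CN(c1ncnc2c1ncn2C1CCCCO1)C1CC1)C(=O)OCc1ccccc1`. In a functional assay on the whole organism (Tail, strain ICR) with Mus musculus as the target, in the tail flick test, with a stated time of 150 min, at a dose of 25 umol/kg by the oral route (a lower number here means a weaker effect, a higher number a stronger effect of the compound at the dose given), compound 1 gives 7.19%, compound 2 gives 6.12% and compound 3 gives 6.53%. Compound 3 thus stands second highest of the three numbers, but all three lie within the scatter of one another, so no order among them can be read. Among the measured compounds shown here, the only measured step, a number 1.1 percentage points lower from compound 1 to compound 2 (within the scatter), concerns a different part of the molecule and does not touch the side chain. The unmeasured compound 4 is `N=C(N)NCCC[C@H](NC(=O)CN(c1ncnc2c1ncn2C1CCCCO1)C1CC1)C(=O)OCc1ccccc1`; it differs from compound 3 by a group of 7 heavy atoms (4 carbon, 3 nitrogen; no ring) in place of a group of 3 heavy atoms (2 carbon, 1 oxygen; no ring), on a saturated chain carbon bound to an amide-type nitrogen and a carbonyl carbon. For the measured compounds named here, no measured step bears on this change. Compound 4 shares its entering group and its ester with compound 2, which gives 6.12%. Going by the values given here, since every number so far sits at the same low level, the expected step is a number 0 percentage points lower from compound 3 to compound 4 (within the scatter), nothing beyond the scatter. Compound 4 is therefore estimated at 6.5%, between 2.5% and 11%.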

Compound 4, a percentage reported as activity, at one dose (the size of the read-out at that dose, not a potency): 19.6%
Beside the measured number, compound 4's estimate is 13.1 percentage points below it, and the stated range ends below it.
By their numbers in this assay, from the lowest: compounds 2, 3 and 1 (each within the scatter of the next); then compound 4.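

In this assay, the saturated chain carbon bound to an amide-type nitrogen and a carbonyl carbon proves to be a place where a change registers: replacing 1-hydroxyethyl with the group of 7 heavy atoms (4 carbon, 3 nitrogen) gives a number 13.1 percentage points higher from compound 3 to compound 4 (beyond the scatter) in this series. The earlier step, benzyl in place of hydrogen on an oxygen next to a carbonyl group, stayed within the scatter, so this is the first change shown to move the read-out. Nothing at hand explains this step.

The compounds shown leave open whether the whole entering group is needed, or whether a chain ending in a simple amine or a carboxylic acid would serve at this carbon. They also leave open whether the step would persist with a free carboxylic acid in place of the benzyl ester of compound 4.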